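The source may report more compounds than this note shows. Statements on the series, on what has been measured and on what is new or still open speak of the compounds shown alone.

Compound 1 `COc1ccccc1Oc1c(N)nc(Cc2ccccc2)nc1OCCO`: 47400 nM
Compound 2 `COc1cccc(-c2nc(N)c(Oc3ccccc3OC)c(OCCO)n2)c1`: 30500 nM
Compound 3 `COc1ccccc1Oc1c(N)nc(-c2ccc(F)cc2)nc1OCCO`: 30100 nM

In a functional assay on B16 cells (Mus musculus) for cytotoxicity, read by CCK-8 assay, with a stated time of 24 h (on this read-out higher numbers stand for weaker inhibition and lower numbers for stronger inhibition), compound 3 stands level with the other two: a 1.0-fold lower number from compound 2 to compound 3 (0.01 log units; within the scatter), and a 1.6-fold lower number from compound 1 to compound 3 (0.20 log units; within the scatter). Compound 4 `COc1ccccc1Oc1c(N)nc(-c2ccc(Br)cc2)nc1OCCO` differs from compound 3 in a single place: bromo in place of fluoro on an aromatic carbon, para to a large group. Among the compounds with values here, no measured pair makes this exact swap. The nearest guides are the exchanges of the whole group carrying it: those two steps and a 1.6-fold lower number from compound 1 to compound 2 (0.19 log units; within the scatter). All stayed within the scatter, so no step beyond the scatter is expected in this assay. The expected step is a 1.1-fold lower number from compound 3 to compound 4 (0.05 log units; within the scatter). Compound 4 is estimated at 27000 nM, with an expected range from 13000 nM to 50000 nM.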

Compound 4, half-maximal inhibitory concentration: 11800 nM
Compound 4: middle estimate off by 2.3-fold (0.36 log units), on the high side; the whole stated range lies above it.
By their numbers in this assay, from the lowest: compound 4; then compounds 3, 2 and 1 (each within the scatter of the next).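

In this assay, within the data shown here, exchanging fluoro for bromo on the outer aromatic ring is the first change here to go beyond the scatter, giving a 2.6-fold lower number from compound 3 to compound 4 (0.41 log units; beyond the scatter). The 4-bromophenyl group also separates from the other groups, with a 2.6-fold lower number from compound 2 to compound 4 (0.41 log units; beyond the scatter) and a 4.0-fold lower number from compound 1 to compound 4 (0.60 log units; beyond the scatter), although benzyl, 3-methoxyphenyl and 4-fluorophenyl could not be told apart. Nothing available explains why bromo and fluoro differ here. Still open, from the compounds shown here alone, is how chloro, iodo or an amine in this same place would read, and whether a cell line other than B16 would show the same step.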